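The source may report more compounds than this note shows. Statements on the series, on what has been measured and on what is new or still open speak of the compounds shown alone.

In a functional assay on PC-3 cells (Homo sapiens) for cytotoxicity, read by MTT assay, with a stated time of 48 h (a lower number here means a stronger inhibitor, a higher number a weaker inhibitor), the measured compounds are:

- compound 1 `COc1cc(-c2noc(N)c2-c2ccc(Cl)cc2)cc(OC)c1OC`: > 50000 nM, a limit
- compound 2 `COc1cc(-c2noc(NC(C)=O)c2-c2ccc(Cl)cc2)cc(OC)c1OC`: 1910 nM
- compound 3 `COc1ccc(-c2c(-c3cc(OC)c(OC)c(OC)c3)noc2N(C(C)=O)C(C)=O)cc1OC`: > 50000 nM, a limit

Compound 3 stands at the limit of > 50000 nM in this assay, at which 2 of the 3 values shown sit, so it offers a limit and not a number. Compound 4 `COc1cc(-c2noc(N(C(C)=O)C(C)=O)c2-c2ccc(Cl)cc2)cc(OC)c1OC` has not yet been measured. It differs from compound 3 by one change: 4-chlorophenyl in place of 3,4-dimethoxyphenyl on an aromatic carbon. The group sits on an aromatic carbon, next to the ring atom that bears a diacetylamino group.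

Within the data shown here, no measured step covers this exchange. The only one, an at least 26-fold lower number from compound 1 to compound 2 (1.41 log units; beyond the scatter), is large but concerns the nitrogen, and the 4-chlorophenyl group stays in place across it. Compound 2 reaches 1910 nM with the 4-chlorophenyl group, which points towards a lower number in this assay. Compound 1 carries the same group and remains at a limit, so the expectation is cautious. The expected step is an at least 3.3-fold lower number from compound 3 to compound 4 (0.52 log units; beyond the scatter). For compound 4 the estimated value is 15000 nM, with an expected range from 2500 nM to 50000 nM.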

Compound 4, half-maximal inhibitory concentration: 2630 nM
Compound 4: middle estimate off by 5.7-fold (0.76 log units), on the high side; measured number inside the range.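

In this assay, among these compounds, replacing the 3,4-dimethoxyphenyl group with the 4-chlorophenyl group gives an at least 19-fold lower number from compound 3 to compound 4 (1.27 log units; beyond the scatter), which shows that this position matters with the diacetylamino group in place, something no earlier step could show. A second acetyl on the amide-type nitrogen gives a 1.4-fold higher number from compound 2 to compound 4 (0.14 log units; within the scatter), so the acetylamino and diacetylamino forms cannot be told apart here, while diacetylamino in place of amino gives an at least 19-fold lower number from compound 1 to compound 4 (1.27 log units; beyond the scatter). Compound 1 and compound 3 each rest on a limit and not a number, so these two large steps are bounds only: the limit of > 50000 nM in this assay, at which 2 of the 4 values shown sit.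

The compounds shown leave open whether a bromine or a methoxy group in place of the chlorine would serve as well at this position. They also leave open how a longer acyl chain, such as propionyl, on the nitrogen would compare.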